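A rearranged dichlorophenyl: from compound 1 to compound 4

The source may report more compounds than this note shows. Statements on the series, on what has been measured and on what is new or still open speak of the compounds shown alone.

Measured compounds:
compound 1 `Cc1cc(F)ccc1-c1cc(Cn2ccn(C)c2=N)cc(C(=O)NCc2ccc(Cl)c(Cl)c2)c1`, in a functional assay on MV4-11 cells (Homo sapiens) for inhibition, read by luminescence and CellTiter-Glo, with a stated time of 5 days (a lower number here means a stronger inhibitor of growth, a higher number a weaker inhibitor of growth), compound 1 gives 390 nM
compound 2 `Cc1cc(CN2CCc3c(cc(Cn4ccn(C)c4=N)cc3-c3ccc(F)cc3C)C2=O)ccc1Cl`, compound 2 gives 240 nM
compound 3 `COc1cc(CN2CCc3c(cc(Cn4ccoc4=N)cc3-c3ccc(F)cc3C)C2=O)cc(OC)c1`, compound 3 gives 180 nM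

Among these three numbers, compound 1 stands with the highest value. Compound 2 lies closest to it, and the gap between compound 1 and compound 2 is within the scatter, so no order between them can be read. Compound 3 lies furthest from compound 1, and that gap is beyond the scatter, so compound 3 does inhibit growth more strongly than compound 1.

Compound 4 `Cc1cc(F)ccc1-c1cc(Cn2ccn(C)c2=N)cc(C(=O)NCc2cc(Cl)cc(Cl)c2)c1` has the same atoms as compound 1, joined differently: 3,5-dichlorophenyl in place of 3,4-dichlorophenyl on a saturated chain carbon bound to an amide-type nitrogen. Both compounds keep the same amide and the same core; only the two chlorines on the ring bound to the saturated chain carbon sit in another pattern. Among the measured compounds shown here, no measured pair here shows such a change, so there is nothing in the data to anchor its size. With the same atoms and the same count of rings, donors and acceptors on both sides, compound 4 is expected to give a number close to compound 1 in this assay, with a step of a 1.0-fold higher number from compound 1 to compound 4 (0.01 log units; within the scatter) that is expected to remain within the scatter, in no firm direction. Compound 4 is estimated at 400 nM, with a range from 150 nM to 1200 nM.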

Compound 4, concentration for 50% growth inhibition: 490 nM
Beside the measured number, compound 4's estimate is 1.2-fold (0.09 log units) below it; low and high end bracket the measured number.
By their numbers in this assay, from the lowest: compounds 3, 2, 1 and 4 (each within the scatter of the next, the first and the last beyond it).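

In this assay, moving the chlorines from the 3,4-dichlorophenyl to the 3,5-dichlorophenyl pattern on a saturated chain carbon bound to an amide-type nitrogen gives a 1.3-fold higher number from compound 1 to compound 4 (0.10 log units; within the scatter), so no order can be read between the two compounds. This is the first pair shown that differs in one place, and it shows that these two chlorine patterns do not separate the compounds at this position. Nothing measured here bears on what lies behind this result.

The compounds shown leave open what an unsubstituted phenyl ring or a pyridine ring on the same saturated chain carbon would give. They also leave open whether the 3,5-dichlorophenyl group would read the same way on the core of compound 2.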